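Nitrone triazoles: benzyl for phenyl on the nitrone nitrogen

The source may hold more compounds than are shown below. What is called first, only, known or untested is meant among the compounds shown, and "the series" means these compounds.

Measured so far:
compound 1, `[O-]/[N+](=C\c1cn(-c2ccccc2)nn1)c1ccccc1`, at the limit of a functional assay on A549 cells (Homo sapiens) for inhibition, read by MTT assay, with a stated time of 24 h; on this read-out higher numbers stand for weaker inhibition and lower numbers for stronger inhibition: > 100000 nM
compound 2, `[O-]/[N+](=C\c1cn(CCC(F)(F)C(F)(F)C(F)(F)C(F)(F)C(F)(F)C(F)(F)C(F)(F)C(F)(F)F)nn1)c1ccccc1`: 86800 nM

In this assay, for the measured compounds named here, compound 2 gives 86800 nM, the only number. Compound 1 sits at the limit of this assay and gives no number. Going by the values given here, no step between measured compounds is available. Compound 3 `[O-]/[N+](=C\c1cn(CCC(F)(F)C(F)(F)C(F)(F)C(F)(F)C(F)(F)C(F)(F)C(F)(F)C(F)(F)F)nn1)Cc1ccccc1` carries benzyl in place of phenyl on a double-bonded nitrogen. With the perfluorinated chain kept and only the group on the nitrone nitrogen altered, the step from compound 2 to compound 3 is expected to be a 1.0-fold higher number from compound 2 to compound 3 (0.02 log units; within the scatter), nothing beyond the scatter. Compound 3 is therefore estimated at 90000 nM, with a range from 30000 nM to 250000 nM.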

Compound 3, half-maximal inhibitory concentration: 8800 nM
The estimate for compound 3 lay 10-fold (1.01 log units) above the measured number; the measured number lies below the stated range.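

On the double-bonded nitrogen the group matters: in this assay, benzyl in place of phenyl gives a 9.9-fold lower number from compound 2 to compound 3 (0.99 log units; beyond the scatter) with the perfluorinated chain kept. For the compounds shown here, this is the first readable step, and it shows that this position alone can move the number beyond the scatter. Nothing measured here accounts for the gain.

As far as these compounds go, whether the step holds with the phenyl group of compound 1 in place of the chain stays open. So does the outcome for a phenethyl group, or for a benzyl carrying an amine on its ring.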